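Sulfonamide heteroaryl variation: cell toxicity working notes

The source may hold more compounds than are shown below. What is called first, only, known or untested is meant among the compounds shown, and "the series" means these compounds.

Measured so far:
compound 1 `C=C1CC[C@@H]2[C@](C)(COC(C)=O)[C@H](OC(C)=O)CC[C@@]2(C)[C@H]1CC(Nc1ccc(S(=O)(=O)Nc2ccc(Cl)nn2)cc1)C1=CCOC1=O` — in a functional assay on MOLT-4 cells (Homo sapiens) for inhibition, read by sulforhodamine B assay, with a stated time of 48 h (on this read-out lower numbers stand for higher toxicity in this test and higher numbers for lower toxicity in this test), compound 1 gives > 100000 nM, a limit of this assay and not a number
compound 2 `C=C1CC[C@@H]2[C@](C)(COC(C)=O)[C@H](OC(C)=O)CC[C@@]2(C)[C@H]1CC(Nc1ccc(S(=O)(=O)Nc2ncccn2)cc1)C1=CCOC1=O` — in this assay compound 2 gives > 100000 nM, again a limit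

Compound 2 thus stands at the upper boundary of what this assay reports; nothing finer is known about it. The step that the two limits leave unreadable from compound 1 to compound 2 is unreadable because both values sit at the limit of > 100000 nM in this assay, at which 2 of the 2 values shown sit.

Compound 3 `C=C1CC[C@@H]2[C@](C)(COC(C)=O)[C@H](OC(C)=O)CC[C@@]2(C)[C@H]1CC(Nc1ccc(S(=O)(=O)Nc2nccs2)cc1)C1=CCOC1=O` is the next member, differing from compound 2 by 1,3-thiazol-2-yl in place of pyrimidin-2-yl on a sulfonamide nitrogen. Among the compounds with values here, no measured step bears on this change: the only step in hand, a step that the two limits leave unreadable from compound 1 to compound 2, is unreadable, so it gives no guide to size or direction. With both measured members at the limit, there is no basis for expecting compound 3 to move into the measurable range.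

Compound 3 is therefore expected at about 150000 nM, in the range 40000 nM to 500000 nM, most probably reported only as a limit. The expected step that the limit leaves unreadable from compound 2 to compound 3 amounts to no change beyond the scatter.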

Compound 3, concentration lethal to 50% of the cells: > 100000 nM
Compound 3: a limit, no number; the forecaster's own chance of this, stated with the estimate: 75%; the middle value lies beyond the limit too.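

No step can be read among compound 1, compound 2 and compound 3, because all three values are limits and not numbers: the limit of > 100000 nM in this assay, at which 3 of the 3 values shown sit.

The compounds shown leave open where the actual values lie in this assay, and whether 6-chloropyridazin-3-yl, pyrimidin-2-yl and 1,3-thiazol-2-yl on the sulfonamide nitrogen differ at all.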